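The source may report more compounds than this note shows. Statements on the series, on what has been measured and on what is new or still open speak of the compounds shown alone.

Measured so far in a functional assay on PC-3 cells (Homo sapiens) for cytotoxicity, read by MTT assay, with a stated time of 72 h; on this read-out higher numbers stand for weaker inhibition and lower numbers for stronger inhibition:
- compound 1 `N#Cc1ccc(/C=N/NC(=O)Nc2cc3c(Nc4ccc(F)c(Cl)c4)ncnc3cc2O[C@H]2CCOC2)cc1`: 28100 nM
- compound 2 `O=C(N/N=C/c1ccc(O)cc1O)Nc1cc2c(Nc3ccc(F)c(Cl)c3)ncnc2cc1O[C@H]1CCOC1`: 7540 nM
- compound 3 `COc1cc2ncnc(Nc3ccc(F)c(Cl)c3)c2cc1NC(=O)N/N=C/c1ccc(C#N)cc1`: 36500 nM

Compound 3 cannot be told apart from its nearest neighbour: a 1.3-fold higher number from compound 1 to compound 3 (0.11 log units; within the scatter). Compound 2 gives the lowest number of the three.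

Compound 4 `COc1ccc(/C=N/NC(=O)Nc2cc3c(Nc4ccc(F)c(Cl)c4)ncnc3cc2OC)cc1` differs from compound 3 by methoxy in place of cyano on an aromatic carbon, or 4-cyanophenyl to 4-methoxyphenyl. Among the compounds with values here, the only measured change to this 4-cyanophenyl group is a 3.7-fold lower number from compound 1 to compound 2 (0.57 log units; beyond the scatter), a modest step, and it brought in a different group. The exchange of methyl for oxolan-3-yl lies elsewhere and has little bearing here. In this assay a small move to a lower number is therefore expected. The expected step is a 1.8-fold lower number from compound 3 to compound 4 (0.26 log units; within the scatter). For compound 4 the estimated value is 20000 nM, with an expected range of 8000 nM to 50000 nM.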

Compound 4, half-maximal inhibitory concentration: 16500 nM
Compound 4: the middle estimate sits 1.2-fold (0.08 log units) above what was measured, and the stated range covers the measured number.
By their numbers in this assay, from the lowest: compound 2; then compounds 4, 1 and 3 (each within the scatter of the next, the first and the last beyond it).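

In this assay, within the data shown here, methoxy in place of cyano on the aromatic carbon gives a 2.2-fold lower number from compound 3 to compound 4 (0.34 log units; beyond the scatter), a modest step and the first reading of an exchange at this carbon alone. Together with a 3.7-fold lower number from compound 1 to compound 2 (0.57 log units; beyond the scatter), where 2,4-dihydroxyphenyl entered on an oxolan-3-yl compound, both listed moves away from 4-cyanophenyl lower the number, with none going against them. No measurement at hand accounts for this shift. Still open, from the compounds shown here alone, is whether the same exchange holds with oxolan-3-yl on the oxygen, and how an amine or a carboxylic acid on this carbon would read.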